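Closing the chain into a piperidine with an acetyl cap

The compounds below may be only part of what the source reports. "The series", "measured", "known", "first", "only" and "open" are said of these compounds alone.

Measured so far:
compound 1 `CCS(=O)(=O)N1CCC(c2cncc(N3C(=O)c4ccc(Cl)cc4C3(C)C)c2)CC1`: 3 nM
compound 2 `CCS(=O)(=O)NCc1cncc(N2C(=O)c3ccc(Cl)cc3C2(C)C)c1`: 92 nM

In an assay on cells for inhibition of cytochrome P450 11B2, mitochondrial (Homo sapiens), read by HTRF (on this read-out higher numbers stand for weaker inhibition and lower numbers for stronger inhibition), compound 2 gives the higher of the two numbers, beyond the scatter from compound 1. Compound 3 `CC(=O)N1CCC(c2cncc(N3C(=O)c4ccc(Cl)cc4C3(C)C)c2)CC1` is not yet measured. For the measured compounds named here, it differs from compound 2 by 1-acetylpiperidin-4-yl in place of ((ethylsulfonyl)amino)methyl on an aromatic carbon, a group that resembles the one in compound 1. On this basis the step of a 12-fold lower number from compound 2 to compound 3 (1.06 log units; beyond the scatter) is expected to be a clear move toward stronger inhibition, though compound 3 may not reach compound 1. Compound 3 is estimated at 8 nM, within 2 nM to 30 nM.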

Compound 3, half-maximal inhibitory concentration: 5 nM
Compound 3: the middle estimate sits 1.6-fold (0.20 log units) above what was measured; the range from low to high includes it.
By their numbers in this assay, from the lowest: compounds 1 and 3 (each within the scatter of the next); then compound 2.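

In this assay, putting 1-acetylpiperidin-4-yl in place of the open ((ethylsulfonyl)amino)methyl gives an 18-fold lower number from compound 2 to compound 3 (1.26 log units; beyond the scatter) and shows that the ethylsulfonyl group is not required for strong inhibition at this position. On the ring nitrogen, acetyl in place of ethylsulfonyl gives a 1.7-fold higher number from compound 1 to compound 3 (0.22 log units; within the scatter) so these two caps cannot be told apart here. No measurement explains either result. From the compounds shown here alone, the step from compound 2 changes ring and cap together, so their separate contributions remain unknown. Going by these compounds, whether a free amine or a longer acyl chain on the ring nitrogen would retain this inhibition also remains open.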